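Notes on the step from compound 3 to compound 4

This account rests on a few compounds, and the source may have more. Where it says the series, first, only, none or still open, it means among the compounds named here.

- compound 1 `N=C(NC(=N)NC1CCCC1)Nc1ccc(C(F)(F)F)cc1` gives 1800 nM
- compound 2 `CC(C)CNC(=N)NC(=N)Nc1ccc(C(F)(F)F)cc1` gives 1300 nM
- compound 3 `CC(C)CNC(=N)NC(=N)Nc1ccc(F)c(F)c1` gives 2400 nM

In a functional assay on A549 cells (Homo sapiens) for antiproliferative activity, read by MTT assay, with a stated time of 72 h (on this read-out higher numbers stand for weaker inhibition and lower numbers for stronger inhibition), compound 3 lies within the scatter of both compound 1 and compound 2, so these values set no order among the three. Compound 4 `CCN(CC)C(=N)NC(=N)Nc1ccc(F)c(F)c1` is still to be measured. The change is diethylamino in place of isobutylamino on a carbon with a double bond to nitrogen with diethylamino in place of isobutylamino on a carbon with a double bond to nitrogen. The nearest measured precedent is a 1.4-fold lower number from compound 1 to compound 2 (0.14 log units; within the scatter) with isobutyl in place of cyclopentyl on an amine nitrogen. Going by the values given here, no measured compound carries diethylamino, so the range stays wide. No step beyond the scatter is expected in this assay and the estimate amounts to a 1.2-fold higher number from compound 3 to compound 4 (0.07 log units; within the scatter) as an expected step. Compound 4 is estimated at 2800 nM (expected range 1100 nM to 7000 nM).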

Compound 4, half-maximal inhibitory concentration: 7800 nM
Beside the measured number, compound 4's estimate is 2.8-fold (0.44 log units) below it; the measured number lies above the stated range.
By their numbers in this assay, from the lowest: compounds 2, 1 and 3 (each within the scatter of the next); then compound 4.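

In this assay, going by these compounds alone, this change at the carbon with a double bond to nitrogen gives a 3.3-fold higher number from compound 3 to compound 4 (0.51 log units; beyond the scatter), the first step beyond the scatter, whereas a 1.4-fold lower number from compound 1 to compound 2 (0.14 log units; within the scatter) showed no response to the amine substituent. Isobutylamino and diethylamino match in heavy atoms, but only isobutylamino carries a hydrogen-bond donor, so rejoining the same atoms is enough to shift the value here. Nothing available explains the step.

Going by these compounds, whether the donor count tracks this step remains open, and ethylamino or piperidinyl on the core of compound 3 would bear on it. Also open, on these data alone, is whether diethylamino gives a similar step on the core of compound 2.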